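Open chain to carbocyclic amide on the aromatic amine nitrogen

The source may report more compounds than this note shows. Statements on the series, on what has been measured and on what is new or still open speak of the compounds shown alone.

Among the measured compounds shown here, compound 1 `FC(F)(F)c1nn(-c2ccc3ncccc3c2)c2nc(Nc3cnn(C4CCNCC4)c3)ncc12` gives 168 nM in an assay on isolated protein for inhibition of eIF-2-alpha kinase GCN2 (Homo sapiens) (on this read-out higher numbers stand for weaker inhibition and lower numbers for stronger inhibition), and serves as the one measured number in the set. Compound 2 `COCCNC(=O)CNc1ncc2c(Br)nn(-c3ccc4ncccc4c3)c2n1` returns only a limit in this assay, > 1000 nM, so no number is known for it. Compound 2 stands at the limit of > 1000 nM in this assay, at which 1 of the 2 values shown sits; what the two values show is that compound 1 is measured and compound 2 is not resolved. Compound 3 `CNC(=O)[C@]1(C)CC[C@@H](Nc2ncc3c(Br)nn(-c4ccc5ncccc5c4)c3n2)C1` differs from compound 2 by a group of 10 heavy atoms (8 carbon, 1 nitrogen, 1 oxygen; one five-membered non-aromatic ring of carbon only) in place of a group of 8 heavy atoms (5 carbon, 1 nitrogen, 2 oxygen; no ring), on a nitrogen on an aromatic ring. For the measured compounds named here, no step between measured compounds is available, and the limit on compound 2 leaves the size of the step open. The step expected is an at least 1.6-fold lower number from compound 2 to compound 3 (0.22 log units; that floor lies within the scatter), read as a move into the measurable range rather than a sized gain. Compound 3 is estimated at 600 nM, within 150 nM to 3000 nM.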

Compound 3, half-maximal inhibitory concentration: 17 nM
For compound 3 the middle estimate is 35-fold (1.55 log units) above the measured one; measured number below the stated range.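

On a nitrogen on an aromatic ring, replacing the open-chain ((2-methoxyethyl)carbamoyl)methyl with the group carrying one five-membered non-aromatic ring of carbon only gives an at least 58-fold lower number from compound 2 to compound 3 (1.76 log units; beyond the scatter) in this assay. With the rest of the structure shared, this position is thus sensitive to the group it carries, and since both groups contain an amide, the amide alone does not separate the two compounds. The step is only a floor because compound 2 stands at a limit: the limit of > 1000 nM in this assay, at which 1 of the 3 values shown sits.

The pair does not show whether the step follows the carbon ring itself or its 2 defined stereocentres. Also open, as far as these compounds go, is whether a six-membered carbon ring, or a carboxylic acid in place of the amide, would retain the value of compound 3 at 17 nM.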